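Methoxy to nitro at the carbonyl aryl of compound 1

A few compounds are considered here, and "the series" means these few. Any claim that something is new, unique, unknown or untested is made for them only; others in the source may bear on it.

Compound 1 `COc1ccc(C(=O)/C=C/c2ccc(OCc3cn(Cc4ccccc4F)nn3)cc2)cc1` carries the 2-fluorophenyl on the saturated chain carbon bound to the aromatic nitrogen. Within the data shown here, in a functional assay on A549 cells (Homo sapiens) for inhibition, read by MTT assay, with a stated time of 48 h, tested at 10 uM (a higher number here means more inhibition of growth at the concentration tested, a lower number less inhibition of growth), compound 1 gives 21% and stands lowest of the three numbers known. Compound 2 `COc1ccc(C(=O)/C=C/c2ccc(OCc3cn(Cc4cccc(F)c4)nn3)cc2)cc1` gives 56% in this assay, and compound 3 `COc1ccc(C(=O)/C=C/c2ccc(OCc3cn(Cc4ccc(F)cc4)nn3)cc2)cc1` gives 33% there. All three known steps exchange one fluorophenyl for another: a number 35 percentage points higher from compound 1 to compound 2 (beyond the scatter), a number 12 percentage points higher from compound 1 to compound 3 (beyond the scatter) and a number 23 percentage points lower from compound 2 to compound 3 (beyond the scatter). Compound 4 `O=C(/C=C/c1ccc(OCc2cn(Cc3ccccc3F)nn2)cc1)c1ccc([N+](=O)[O-])cc1` differs from compound 1 in another way: nitro in place of methoxy on an aromatic carbon. Among the measured compounds shown here, none of the measured steps touches that part of the core, so they give no direction and no size for this change. Compound 4 is therefore expected near compound 1, estimated at 28% within 8% to 58%. The estimated step is a number 7 percentage points higher from compound 1 to compound 4 (within the scatter), expected within the scatter.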

Compound 4, percent growth inhibition at one concentration: 43%
The estimate for compound 4 lay 15 percentage points below the measured number; the range from low to high includes it.
By their numbers in this assay, from the lowest: compound 1; then compounds 3 and 4 (each within the scatter of the next); then compound 2.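

In this assay, the carbonyl aryl position proves responsive: nitro in place of methoxy gives a number 22 percentage points higher from compound 1 to compound 4 (beyond the scatter) on the 2-fluorophenyl background. The fluorophenyl is therefore not the only part of the series where a single change moves growth inhibition beyond the scatter. No available evidence bears on why this exchange raises the number.

Still open, as far as these compounds go, is whether nitro gives a similar step with the fluorine placement of compound 2 or compound 3. Also open, from the compounds shown here alone, is where an amine or a carboxylic acid on this aromatic carbon would stand.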